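Methyl to hydrogen on the arylamino group of compound 1

The compounds below may be only part of what the source reports. "The series", "measured", "known", "first", "only" and "open" are said of these compounds alone.

Measured in a functional assay on MCF7 cells (Homo sapiens) for inhibition, read by sulforhodamine B assay (on this read-out lower numbers stand for stronger inhibition and higher numbers for weaker inhibition), so far:
compound 1 `Cc1ccc(NC2=CC(=O)c3nc4n(c3C2=O)[C@H]2OC[C@@H](O)[C@H]2OC4)cc1`: 1660 nM
compound 2 `O=C1C(N2CCCCC2)=CC(=O)c2c1nc1n2[C@H]2OC[C@@H](O)[C@H]2OC1`: > 8000 nM
compound 3 `COc1ccccc1NC1=CC(=O)c2c(nc3n2[C@H]2OC[C@@H](O)[C@H]2OC3)C1=O`: 6580 nM

Compound 1 stands lowest of the two numbers; compound 3 sits higher by a gap beyond the scatter. For compound 2 only a limit of this assay is known, (the limit of > 8000 nM in this assay, at which 1 of the 3 values shown sits). Within the data shown here, the one measured step is an at least 1.2-fold lower number from compound 2 to compound 3 (0.08 log units; that floor lies within the scatter), an exchange of the whole amine, and its floor lies within the scatter.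

Compound 4 `O=C1C=C(Nc2ccccc2)C(=O)c2c1nc1n2[C@H]2OC[C@@H](O)[C@H]2OC1` differs from compound 1 by hydrogen in place of methyl on an aromatic carbon. Among the measured compounds shown here, no measured step touches this change, so no shift beyond the scatter is expected in this assay. Compound 4 is estimated at 2500 nM, within 900 nM to 7000 nM. The expected step is a 1.5-fold higher number from compound 1 to compound 4 (0.18 log units; within the scatter).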

Compound 4, half-maximal inhibitory concentration: > 4000 nM
Compound 4 was reported as a limit (the forecaster's own chance of this, stated with the estimate: 10%); middle value at least 1.6-fold (0.20 log units) away from the limit.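

In this assay, replacing the methyl of the 4-methylphenyl group with hydrogen gives an at least 2.4-fold higher number from compound 1 to compound 4 (0.38 log units; beyond the scatter). Among these compounds, this is the first single-atom change at this place on the arylamino group, whereas the earlier step exchanged the whole amine, and it shows that this one methyl carries a difference beyond the scatter. Its true size remains unknown, and the step gives only a floor: the limit of > 4000 nM in this assay, at which 1 of the 4 values shown sits.

Going by these compounds, whether ethyl or chlorine on the same aromatic carbon would match or improve on the methyl remains open. Also open, on these data alone, is how far a longer chain such as butyl could be carried there.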